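Two halogenated aryl groups on the shared core

The source may hold more compounds than are shown below. What is called first, only, known or untested is meant among the compounds shown, and "the series" means these compounds.

The shared core of compound 1 `C=CCn1c(=O)/c(=C\c2cccc(Br)c2)[nH]c(=O)/c1=C\c1ccccc1OC` carries a 2-methoxyphenyl group and a 3-bromophenyl group. In a functional assay on BGC-823 cells (Homo sapiens) for cytotoxicity, read by CCK-8 assay, with a stated time of 72 h (on this read-out lower numbers stand for stronger inhibition and higher numbers for weaker inhibition), compound 1 gives 5900 nM, the highest of the numbers known. Compound 3 `COc1ccccc1/C=c1/[nH]c(=O)/c(=C\c2nc[nH]c2C(C)(C)C)[nH]c1=O` gives 90 nM in this assay, and compound 2 `C=CCn1c(=O)/c(=C\c2cccc(Br)c2)[nH]c(=O)/c1=C\c1cccc(Br)c1`, which carries two 3-bromophenyl groups, is reported in this assay as "not active" (no number reported). Compound 4 `C=CCn1c(=O)/c(=C\c2cccc(Cl)c2Cl)[nH]c(=O)/c1=C\c1ccccc1OC` differs from compound 1 in one place: 2,3-dichlorophenyl in place of 3-bromophenyl on a double-bonded chain carbon bound to an aromatic carbon. Within the data shown here, compound 2 shows that adding a halogenated aryl group costs activity, and no step between measured compounds tells how one halogenated aryl group compares with another. Compound 4 is therefore expected to stay close to compound 1, with a step of a 1.0-fold higher number from compound 1 to compound 4 (0.01 log units; within the scatter) that lies within the scatter, and its estimated value in this assay is 6000 nM, ranging from 1500 nM to 25000 nM.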

Compound 4, half-maximal inhibitory concentration: 2200 nM
Compound 4: middle estimate off by 2.7-fold (0.44 log units), on the high side; the range from low to high includes it.
By their numbers in this assay, from the lowest: compound 3; then compound 4; then compound 1.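

In this assay, 2,3-dichlorophenyl in place of 3-bromophenyl on a double-bonded chain carbon bound to an aromatic carbon gives a 2.7-fold lower number from compound 1 to compound 4 (0.43 log units; beyond the scatter) as a modest step beyond the scatter. Among these compounds, this shows that the number at this position depends on which halogenated aryl group it carries, something the earlier compounds could not show. No measurement at hand says why the number moves.

The compounds shown leave open whether the step follows from the change of halogen or from the second halogen. They also leave open how a 3-chlorophenyl group, or a phenyl group carrying an amine or a carboxylic acid, would compare at this position.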